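The compounds below may be only part of what the source reports. "The series", "measured", "known", "first", "only" and "open" are said of these compounds alone.

Measured so far, in an assay on membranes from brain for binding affinity to Lysophosphatidylserine lipase ABHD12 (Mus musculus), read by fluorescence, with a stated time of 20 min; a higher number here means a weaker inhibitor, a lower number a stronger inhibitor:
compound 1 `FC(F)(F)Oc1ccc(Oc2ccnc(N3CCC(NC(=S)Nc4cccnc4)CC3)c2Cl)cc1` gives 25 nM
compound 2 `FC(F)(F)Oc1ccc(Oc2ccnc(N3CCC(NC(=S)Nc4cccnc4)CC3)c2)cc1` gives 410 nM
compound 3 `FC(F)(F)c1ccnc(N2CCC(NC(=S)Nc3cccnc3)CC2)c1` gives 640 nM

Compound 4 `FC(F)(F)c1cc(N2CCC(NC(=S)Nc3cccnc3)CC2)ncc1Cl` has not yet been measured in this assay. The change from compound 2 to compound 1 is chloro in place of hydrogen on an aromatic carbon, and that single change made a step of a 16-fold lower number from compound 2 to compound 1 (1.21 log units; beyond the scatter). Compound 4 carries the same kind of change on compound 3: chloro in place of hydrogen on an aromatic carbon. The two places are not identical, though: in compound 1 the chloro sits ortho to two large groups, whereas in compound 4 it sits ortho to a trifluoromethyl group (4 heavy atoms) and para to a large group. How the core of compound 3 differs from the core of compound 2 is not broken down here; the values of compound 2 and compound 3 in this assay lie within the usual scatter of each other.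

For compound 4 a step of a 4.9-fold lower number from compound 3 to compound 4 (0.69 log units; beyond the scatter) is expected, smaller than the earlier step because the step of a 16-fold lower number from compound 2 to compound 1 (1.21 log units; beyond the scatter) was seen on a different core with different surroundings. Compound 4 is therefore estimated at 130 nM, with a likely span from 40 nM to 400 nM.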

Compound 4, half-maximal inhibitory concentration: 1400 nM
Beside the measured number, compound 4's estimate is 11-fold (1.03 log units) below it; the measured number lies above the stated range.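

In this assay, chloro in place of hydrogen on an aromatic carbon gave a 2.2-fold higher number from compound 3 to compound 4 (0.34 log units; beyond the scatter), so the gain seen on the other core did not carry over and the direction of the step reversed. Carried from one core to another, the same change therefore gave clearly different results: the same change on two cores in this assay, a 16-fold lower number (1.21 log units; beyond the scatter) from compound 2 to compound 1 and a 2.2-fold higher number (0.34 log units; beyond the scatter) from compound 3 to compound 4, 36-fold (1.55 log units) apart, beyond the scatter of two such steps This shows that the result of adding this chloro cannot simply be transferred within the series, but it does not show whether the difference comes from the rest of the core or from where the chloro sits, since the two pairs differ in both and two pairs give no general rule.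

Still open, as far as these compounds go, is whether a methyl group, a nitrile or a methoxy group at the place of the chloro in compound 4 would shift the number in either direction. Also open, from the compounds shown here alone, is how a chloro on another carbon of the same ring would behave on the core of compound 3.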